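The source may report more compounds than this note shows. Statements on the series, on what has been measured and on what is new or still open speak of the compounds shown alone.

Measured in an assay on isolated protein (Oryctolagus cuniculus) with Thromboxane-A synthase (Homo sapiens) as the target, tested at 1 uM; on this read-out lower numbers stand for less inhibition and higher numbers for more inhibition at the one concentration tested (going by the name of the read-out):

compound 1, `CCn1nc(-c2cccnc2)c2ccccc2c1=O`: 87%
compound 2, `CC(=O)OCCn1nc(-c2cccnc2)c2ccccc2c1=O`: 32%
compound 3, `O=c1c2ccccc2c(-c2cccnc2)nn1CCSc1ncccn1`: 86%

Compound 1 stands highest of the three numbers in this assay, though its gap to compound 3 is within the scatter, so the two numbers count as level; compound 2 alone lies well apart, shown by the step of a number 55 percentage points lower from compound 1 to compound 2 (beyond the scatter).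

Compound 4, `O=C(O)CCCn1nc(-c2cccnc2)c2ccccc2c1=O`, differs from compound 1 by carboxymethyl in place of hydrogen on a saturated chain carbon, two bonds along the chain from an aromatic nitrogen. Two measured steps start from the same place on compound 1. The step of a number 1 percentage points lower from compound 1 to compound 3 (within the scatter) shows that an added group there can leave inhibition unchanged, while the step of a number 55 percentage points lower from compound 1 to compound 2 (beyond the scatter) shows that another added group there can cut it sharply. The entering carboxymethyl is neither of those groups, so the data give no firm direction; a drop is possible but not certain. A moderate fall in this assay is therefore expected for compound 4, a number 27 percentage points lower from compound 1 to compound 4 (beyond the scatter). Compound 4 is estimated at 60%, with a range from 30% to 88%.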

Compound 4, a percentage reported as inhibition, at one concentration (the size of the read-out at that concentration, not a potency): 73%
For compound 4 the middle estimate is 13 percentage points below the measured one; measured number inside the range.
By their numbers in this assay, from the lowest: compound 2; then compound 4; then compounds 3 and 1 (each within the scatter of the next).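

In this assay, the position on the saturated chain carbon now shows an intermediate outcome as well as the unchanged and sharply reduced ones: carboxymethyl gives a number 14 percentage points lower from compound 1 to compound 4 (beyond the scatter). The same group also separates from both earlier substituents at this place, with a number 13 percentage points lower from compound 3 to compound 4 (beyond the scatter) and a number 41 percentage points higher from compound 2 to compound 4 (beyond the scatter), so the three groups give three distinct levels of inhibition, with compound 1 and compound 3 level at the top. Nothing available explains these differences among the groups.

On these data alone, whether the result for compound 4 depends on the carboxylic acid itself or on the chain that carries it remains open. A methyl ester or an amine at the end of the same chain, or a longer chain ending in a carboxylic acid, would help separate these two readings.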